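The source may hold more compounds than are shown below. What is called first, only, known or untested is meant among the compounds shown, and "the series" means these compounds.

Compound 1 `COc1cc(C(F)(F)F)cc(C(F)(F)F)c1C(=O)NC1(c2ccccc2)CCCN(CC2CC2)C1`: 380 nM
Compound 2 `CN1CCCC(NC(=O)c2ccc(C(F)(F)F)cc2F)(c2ccccc2)C1`: 9900 nM
Compound 3 `COc1ccc(C2(NC(=O)c3c(OC)cc(C(F)(F)F)cc3SC)CCCN(C)C2)cc1`: 170 nM

These three compounds have been tested in an assay on cells for inhibition of sodium- and chloride-dependent glycine transporter 1 (Homo sapiens); a lower number here means that less compound is needed, a higher number that more compound is needed for the effect. Compound 3 has the lowest number of the three. Its nearest neighbour is compound 1, whose number is higher by a gap that lies beyond the usual scatter of this assay, and compound 2 lies far further away. No two of the measured compounds differ in only one place, so none of these gaps can be traced to a single structural change; each pair differs in several parts at once.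

Compound 4 `COc1cc(C(F)(F)F)cc(SC)c1C(=O)NC1(c2ccncc2)CCCN(C)C1` has not yet been measured. It is built from compound 3 by one change: pyridin-4-yl in place of 4-methoxyphenyl on a saturated ring carbon. The amide, the acyl ring carrying the methoxy, trifluoromethyl and methylthio groups, and the methyl on the ring nitrogen all stay as they are in compound 3. For the measured compounds named here, no measured pair shows what this swap does on this core, so the expectation rests on compound 3 alone and is held loosely. The step from compound 3 to compound 4 is expected to be small and toward a higher number, roughly a 2.4-fold higher number from compound 3 to compound 4 (0.37 log units; beyond the scatter), possibly within the scatter. Compound 4 is therefore expected to give about 400 nM, with a range from 120 nM to 1500 nM.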

Compound 4, half-maximal effective concentration: 60 nM
The estimate for compound 4 lay 6.7-fold (0.82 log units) above the measured number; the whole stated range lies above it.
By their numbers in this assay, from the lowest: compound 4; then compound 3; then compound 1; then compound 2.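

In this assay, putting pyridin-4-yl in place of 4-methoxyphenyl on the saturated ring carbon gives a 2.8-fold lower number from compound 3 to compound 4 (0.45 log units; beyond the scatter), a modest step but one beyond the usual scatter. For the compounds shown here, this is the first difference in the set that can be traced to one place, and it shows that this position accepts an aromatic ring with a nitrogen in it, with fewer heavy atoms than the group it replaces, without any loss in this measurement. Both groups count the same number of hydrogen-bond acceptors, so that count does not separate them, and no measurement here explains why the number falls.

As far as these compounds go, it remains open whether the gain comes from the ring nitrogen itself or from losing the methoxy group, a question that an unsubstituted phenyl on this same core could help settle, and whether the location of the nitrogen matters, as pyridin-3-yl or pyridin-2-yl would show. It is also unclear whether a ring with two nitrogens, such as pyrimidin-5-yl, would continue the trend or reverse it.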